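The compounds below may be only part of what the source reports. "The series", "measured", "known", "first", "only" and "open" are said of these compounds alone.

Measured compounds in an assay on Prostate gland for inhibition of steroid 5-alpha-reductase (Rattus norvegicus); a higher number here means a weaker inhibitor, a lower number a stronger inhibitor:
Compound 1 `CCCCCn1ccc2cc(/C(C)=C/C(=O)Nc3ccccc3OCCCC(=O)O)ccc21` gives 23 nM.
Compound 2 `CCCC(CC)n1ccc2cc(/C(C)=C/C(=O)Nc3ccccc3OCCCC(=O)O)ccc21` gives 9.3 nM.
Compound 3 `C/C(=C\C(=O)Nc1ccccc1OCCCC(=O)O)c1ccc2c(ccn2Cc2ccc(C)cc2)c1` gives 88 nM.

Compound 3 has the highest number of the three and is thus the weakest inhibitor among them: the step of a 3.8-fold higher number from compound 1 to compound 3 (0.58 log units; beyond the scatter) separates it from compound 1, and the step of a 9.5-fold higher number from compound 2 to compound 3 (0.98 log units; beyond the scatter) from compound 2, both beyond the scatter.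

Compound 4 `CCCCC(c1ccccc1)n1ccc2cc(/C(C)=C/C(=O)Nc3ccccc3OCCCC(=O)O)ccc21` differs from compound 3 by 1-phenylpentyl in place of 4-methylbenzyl on an aromatic nitrogen. The entering group keeps a six-membered aromatic ring of carbon only, as in compound 3, but also carries a longer chain on the carbon bound to the aromatic nitrogen, resembling the 1-ethylbutyl of compound 2. Among the measured compounds shown here, two measured steps bear on this: the step of a 3.8-fold higher number from compound 1 to compound 3 (0.58 log units; beyond the scatter) shows that the aryl-bearing group cost potency relative to a plain chain, and the step of a 2.5-fold lower number from compound 1 to compound 2 (0.39 log units; beyond the scatter) shows that branching of the chain on that carbon gave a modest gain. Compound 4 combines both features, so a lower number than compound 3 is expected, estimated as a 4.4-fold lower number from compound 3 to compound 4 (0.64 log units; beyond the scatter). Compound 4 is therefore expected to give about 20 nM, within a range from 7 nM to 60 nM.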

Compound 4, half-maximal inhibitory concentration: 9.8 nM
Estimate against measurement, compound 4: 2.0-fold (0.31 log units) above; the range from low to high includes it.
By their numbers in this assay, from the lowest: compounds 2 and 4 (each within the scatter of the next); then compound 1; then compound 3.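

At the aromatic nitrogen, a phenyl ring does not by itself go with weak inhibition: in this assay, 1-phenylpentyl in place of 4-methylbenzyl gives a 9.0-fold lower number from compound 3 to compound 4 (0.95 log units; beyond the scatter) and so recovers the potency missing from the benzyl group. Against the all-carbon chain branch, 1-phenylpentyl in place of 1-ethylbutyl gives a 1.1-fold higher number from compound 2 to compound 4 (0.02 log units; within the scatter) and the two groups cannot be told apart here. Phenyl in place of hydrogen on the saturated chain carbon gives a 2.3-fold lower number from compound 1 to compound 4 (0.37 log units; beyond the scatter), so a branch on that carbon goes with a lower number whether it is a chain or a ring, as the two branched compounds show.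

As far as these compounds go, whether a cyclohexyl ring or a shorter chain, as in 1-phenylethyl, would hold this level remains open. Nothing available accounts for these differences.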